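The source may report more compounds than this note shows. Statements on the series, on what has been measured and on what is new or still open speak of the compounds shown alone.

Among the compounds with values here, compound 1 `CCCC(N)C(=O)NCc1ccccc1` is the one compound with a number in a functional assay on the whole organism (strain NMRI) with Mus musculus as the target, in the maximal electroshock model, with a stated time of 30 min (on this read-out higher numbers stand for an effect only at larger amounts of compound and lower numbers for an effect already at smaller amounts), where compound 1 gives 39 mg/kg. Compound 2 `N[C@H](CCO)C(=O)NCc1ccccc1` reaches only a limit of the assay in this assay, giving > 160 mg/kg. Within the data shown here, the single measured step, an at least 4.1-fold higher number from compound 1 to compound 2 (0.61 log units; beyond the scatter), runs toward a weaker effect, the limit being (the limit of > 160 mg/kg in this assay, at which 1 of the 2 values shown sits). Compound 3 `C#CCOCC(N)C(=O)NCc1ccccc1` differs from compound 1 by propargyloxy in place of ethyl on a saturated chain carbon, two bonds along the chain from an amine nitrogen and a carbonyl carbon. That change brings an ether oxygen into the side chain, not a hydroxyl as in compound 2, so only part of that loss is expected. Compound 3 is expected to show a 1.7-fold higher number from compound 1 to compound 3 (0.22 log units; within the scatter). Compound 3 is estimated at 65 mg/kg, within 25 mg/kg to 160 mg/kg.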

Compound 3, dose for half-maximal effect: 46 mg/kg
Beside the measured number, compound 3's estimate is 1.4-fold (0.15 log units) above it, and the stated range covers the measured number.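

In this assay, the position takes the larger propargyloxy group, with its ether oxygen and triple bond, in place of ethyl without a loss beyond the scatter, at a 1.2-fold higher number from compound 1 to compound 3 (0.07 log units; within the scatter). An oxygen in the side chain therefore does not by itself bring the loss seen with compound 2, whose value is a limit of the assay: the limit of > 160 mg/kg in this assay, at which 1 of the 3 values shown sits.

The compounds shown leave open how the ether oxygen and the triple bond each contribute, as a propoxy or methoxy group would tell. They also leave open whether an amine or a carboxylic acid at the end of the side chain is accepted here.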